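The source may report more compounds than this note shows. Statements on the series, on what has been measured and on what is new or still open speak of the compounds shown alone.

Of the compounds shown here, three have been measured in a functional assay on KG-1 cells (Homo sapiens) for cytotoxicity, read by luminescence and CellTiter-Glo, with a stated time of 3 days; on this read-out higher numbers stand for weaker inhibition and lower numbers for stronger inhibition. Compound 1 `N#Cc1ccc(NC(=O)c2cc(Cc3ccccc3)ccc2O)cc1` gives 1930 nM. Compound 2 `O=C(Nc1ccc(Cl)cc1)c1ccc2cccnc2c1O` gives 3300 nM. Compound 3 `O=C(Nc1cc(Cl)cc(Cl)c1)c1cc(F)ccc1O` gives 780 nM. On these numbers compound 1 stands second highest of the three: its number sits within the scatter of that of compound 2, while compound 3 lies lower than compound 1 by a margin beyond the scatter. Compound 4 `N#Cc1ccc(NC(=O)c2cc(-c3ccccc3)ccc2O)cc1` remains to be measured. It differs from compound 1 by phenyl in place of benzyl on an aromatic carbon. Among the measured compounds shown here, no measured pair in this set shares that change, so the expected step in this assay has no prior anchor. A small step, none beyond the scatter, is expected a 1.2-fold lower number from compound 1 to compound 4 (0.08 log units; within the scatter). Compound 4 is estimated at 1600 nM, with a range from 500 nM to 5000 nM.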

Compound 4, half-maximal inhibitory concentration: 1300 nM
For compound 4 the middle estimate is 1.2-fold (0.09 log units) above the measured one; the range from low to high includes it.
By their numbers in this assay, from the lowest: compounds 3, 4, 1 and 2 (each within the scatter of the next, the first and the last beyond it).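

In this assay, phenyl in place of benzyl on the aromatic carbon para to a hydroxy group gives the first step read at this position (a 1.5-fold lower number from compound 1 to compound 4 (0.17 log units; within the scatter)). This step is within the scatter, so the assay does not separate these two groups here. No measurement on hand bears on why the two groups read this way.

Going by these compounds, whether a group without an aromatic ring, such as an amine, a carboxylic acid or a longer chain, would give a step beyond the scatter at this carbon remains open.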